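The source may hold more compounds than are shown below. What is called first, only, known or untested is meant among the compounds shown, and "the series" means these compounds.

In an ADME assay on HUVEC cells (Homo sapiens) for cytotoxicity, read by MTT assay, with a stated time of 48 h (a higher number here means a weaker inhibitor, a lower number a stronger inhibitor), the three measured compounds stand as follows.

compound 1, `Nc1nc(-c2ccccc2)cn1/N=C/c1cc2ccccc2nc1Cl`: 46700 nM
compound 2, `Cc1ccc(-c2cn(/N=C/c3cc4ccccc4nc3Cl)c(N)n2)cc1`: > 50000 nM, a limit of the assay rather than a number
compound 3, `Nc1nc(-c2cccs2)cn1/N=C/c1cc2ccccc2nc1Cl`: 10200 nM

Compound 2 carries methyl in place of hydrogen on an aromatic carbon against compound 1, and the step is an at least 1.0-fold higher number from compound 1 to compound 2 (0.02 log units; that floor lies within the scatter). That reading rests on (the limit of > 50000 nM in this assay, at which 1 of the 3 values shown sits). Compound 3 differs from compound 1 in the core, and the step is a 4.6-fold lower number from compound 1 to compound 3 (0.66 log units; beyond the scatter). Between compound 2 and compound 3 the step is an at least 4.9-fold lower number from compound 2 to compound 3 (0.69 log units; beyond the scatter). Compound 3 has the lowest of the two numbers given, with compound 1 nearest.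

Compound 4, `Cc1ccc2nc(Cl)c(/C=N/n3cc(-c4cccs4)nc3N)cc2c1`, is not yet measured. It differs from compound 3 by methyl in place of hydrogen on an aromatic carbon. Among the measured compounds shown here, this is the same kind of change as the one from compound 1 to compound 2, but not the same: there the methyl enters on a six-membered aromatic ring of carbon only, para to a large group; here it enters on a six-membered aromatic ring of carbon only that is part of a fused or bridged system of two rings, meta to a fused ring and para to a fused ring. The cores of compound 3 and compound 1 differ by thiophen-2-yl in place of phenyl on an aromatic carbon.

Beside the earlier methyl step an at least 1.0-fold higher number from compound 1 to compound 2 (0.02 log units; that floor lies within the scatter), which sits at its floor within the scatter, the step from compound 3 to compound 4 is expected to be a 1.4-fold higher number from compound 3 to compound 4 (0.14 log units; within the scatter) in this assay. Compound 4 is therefore estimated at 14000 nM, with a range from 5000 nM to 40000 nM.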

Compound 4, half-maximal inhibitory concentration: 38000 nM
The estimate for compound 4 lay 2.7-fold (0.43 log units) below the measured number; the measured number falls inside the stated range.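

In this assay, methyl in place of hydrogen on an aromatic carbon, here on a six-membered aromatic ring of carbon only that is part of a fused or bridged system of two rings, gives a 3.7-fold higher number from compound 3 to compound 4 (0.57 log units; beyond the scatter). So on the core of compound 3 this change moves the number upward by a step that can be read, but the series does not show whether a step of that size carries over from the earlier core, and the comparison also spans a different ring as the place of the methyl: the same change on two cores in this assay, an at least 1.0-fold higher number (0.02 log units; that floor lies within the scatter) from compound 1 to compound 2 and a 3.7-fold higher number (0.57 log units; beyond the scatter) from compound 3 to compound 4; the limit leaves it open whether they differ. Compound 2 stands at a limit of the assay and not at a number, so the earlier step gives only a floor and no size to set against the new one: the limit of > 50000 nM in this assay, at which 1 of the 4 values shown sits.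

The compounds shown leave open whether methyl on the ring of the fused system would give a similar step on the core of compound 1, and whether methyl on the ring that carries it in compound 2 would do so on the core of compound 3. As far as these compounds go, it also remains open whether another group at the place of the methyl in compound 4, such as ethyl, methoxy or an amine, would move the number in the same direction.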